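Trading bromo for a shifted trifluoromethyl group

The compounds below may be only part of what the source reports. "The series", "measured", "known", "first", "only" and "open" are said of these compounds alone.

Of the compounds shown here, two that share one core have so far been measured in a functional assay on NCI-H460 cells (Homo sapiens) for inhibition, read by MTT assay, with a stated time of 72 h; on this read-out lower numbers stand for stronger inhibition and higher numbers for weaker inhibition. Compound 1 (`COc1cc(NC(C)CCCNC(=O)NNC(=O)Nc2ccc(C(F)(F)F)cc2)c2ncccc2c1`) gives 12000 nM and compound 2 (`COc1cc(NC(C)CCCNC(=O)NNC(=O)Nc2ccc(Br)cc2)c2ncccc2c1`) gives 27000 nM as the higher of the two numbers, which places compound 2 on the weaker side of this small set. The next compound is compound 3 (`COc1cc(NC(C)CCCNC(=O)NNC(=O)Nc2cccc(C(F)(F)F)c2)c2ncccc2c1`), which has 3-(trifluoromethyl)phenyl in place of 4-bromophenyl on an amide-type nitrogen. Within the data shown here, only one measured step bears on this change. It runs a 2.3-fold higher number from compound 1 to compound 2 (0.35 log units; beyond the scatter) with bromo in place of trifluoromethyl on an aromatic carbon, and it is modest but beyond the scatter. Compound 3 carries trifluoromethyl again, so that step is read in reverse. Among the measured compounds shown here, the group is not placed as in compound 1, however, and no measured pair shows what that difference alone does. A modest move to a lower number is therefore expected, with the estimated change being a 2.1-fold lower number from compound 2 to compound 3 (0.32 log units; beyond the scatter) in this assay on this reasoning. For compound 3 the estimated value is 13000 nM with an expected range from 6000 nM to 28000 nM in this measurement.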

Compound 3, half-maximal inhibitory concentration: 20000 nM
The estimate for compound 3 lay 1.5-fold (0.19 log units) below the measured number; the range from low to high includes it.
By their numbers in this assay, from the lowest: compounds 1, 3 and 2 (each within the scatter of the next, the first and the last beyond it).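

In this assay the exchange of 4-bromophenyl for 3-(trifluoromethyl)phenyl on the amide-type nitrogen comes out as a 1.4-fold lower number from compound 2 to compound 3 (0.13 log units; within the scatter) and so, unlike the exchange of trifluoromethyl for bromo in the earlier step, it does not separate the two compounds. Among these compounds, the new compound also gives the first direct comparison of 3-(trifluoromethyl)phenyl with 4-(trifluoromethyl)phenyl at this place, and a 1.7-fold higher number from compound 1 to compound 3 (0.22 log units; within the scatter) shows that this difference does not separate them either, leaving compound 3 indistinguishable from both compound 1 and compound 2 even though those two remain apart. Nothing available here gives a measured reason for any of these numbers.

The compounds shown leave open whether 3-bromophenyl would track 4-bromophenyl or 3-(trifluoromethyl)phenyl, which would show how the identity of the substituent and its place on the phenyl ring bear on the read-out separately. They also leave open whether a quite different group on this ring, such as an amine or a carboxylic acid, would shift the number beyond the scatter in either direction.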